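A few compounds are considered here, and "the series" means these few. Any claim that something is new, unique, unknown or untested is made for them only; others in the source may bear on it.

Two compounds of a shared core, in which an amide links an aminophenyl group to a benzyl dithiocarbamate, have been measured in a functional assay on MGC-803 cells (Homo sapiens) for antiproliferative activity, read by CCK-8 assay, with a stated time of 72 h, tested at 2 uM; a higher number here means a stronger effect of the compound at the concentration tested, a lower number a weaker effect. Compound 1, `CC1CCCCN1C(=S)SCc1ccc(C(=O)Nc2ccccc2N)cc1`, carries a methyl-substituted piperidine on the dithiocarbamate and gives 64.4%. Compound 2, `Nc1ccccc1NC(=O)c1ccc(CSC(=S)N2CCN(Cc3ccncc3)CC2)cc1`, carries instead a piperazine bearing a (pyridin-4-yl)methyl group and gives 18.4%, the lowest of the two numbers; the nearest number, that of compound 1, stands well beyond the usual scatter above it.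

Compound 3, `N#Cc1ccc(N2CCN(C(=S)SCc3ccc(C(=O)Nc4ccccc4N)cc3)CC2)cc1`, keeps the core and the piperazine of compound 2 and differs in one place: 4-cyanophenyl in place of (pyridin-4-yl)methyl on an amine nitrogen in a ring. For the measured compounds named here, no measured pair shows the effect of this exchange, so the size of the step from compound 2 to compound 3 is not known from the data. Since only the two numbers above are available, a modest upward move is expected from compound 2 to compound 3, a number 16.6 percentage points higher from compound 2 to compound 3 (beyond the scatter), with wide uncertainty. On that basis compound 3 is estimated to reach 35% in this assay, within a range from 10% to 65%.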

Compound 3, a percentage reported as inhibition, at one concentration (the size of the read-out at that concentration, not a potency): 34.5%
The estimate for compound 3 lay 0.5 percentage points above the measured number, and the stated range covers the measured number.
By their numbers in this assay, from the lowest: compound 2; then compound 3; then compound 1.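

Within the shared core, the amine nitrogen of the piperazine responds to what it carries: in this assay the exchange of (pyridin-4-yl)methyl for 4-cyanophenyl gives a number 16.1 percentage points higher from compound 2 to compound 3 (beyond the scatter) and so moves the read-out by more than the usual scatter, something compound 1 and compound 2 could not show, as they differ in more than this one group. The two groups have a six-membered aromatic ring in common and match in their counts of hydrogen-bond donors and acceptors and in having no net charge, yet the exchange removes the ring nitrogen, adds a nitrile and drops the methyl link to the ring, all in one step. Nothing measured here separates these changes or explains the step.

A plain phenyl group and a benzyl group on the same nitrogen would show how much of the step follows the nitrile, the ring nitrogen or the link. A 4-methoxyphenyl or 3-cyanophenyl group there would test whether the nitrile matters at all and whether its place on the ring does.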